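Propargyl to Substituted Benzyl on the Ring Amine

The source may hold more compounds than are shown below. What is called first, only, known or untested is meant among the compounds shown, and "the series" means these compounds.

In a functional assay on HeLa cells (Homo sapiens) for cytotoxicity, read by MTT assay, with a stated time of 48 h (on this read-out higher numbers stand for weaker inhibition and lower numbers for stronger inhibition), compound 3 `C#CCN1CCN(CC(=O)N2CCN(c3ccc(C(=O)c4cc5ccc(N(CC)CC)cc5o4)cc3)CC2)CC1` gives only a limit of the assay, > 40000 nM. Compound 1 `CCN(CC)c1ccc2cc(C(=O)c3ccc(N4CCN(C(=O)CN5CCN(S(=O)(=O)c6ccc(C#N)cc6)CC5)CC4)cc3)oc2c1` gives 8470 nM in this assay, and compound 2 `CCN(CC)c1ccc2cc(C(=O)c3ccc(N4CCN(C(=O)CN5CCN(S(=O)(=O)c6ccc(F)cc6)CC5)CC4)cc3)oc2c1` gives 16700 nM. Compound 3 is the weakest of the three, as the steps of an at least 4.7-fold higher number from compound 1 to compound 3 (0.67 log units; beyond the scatter) and an at least 2.3-fold higher number from compound 2 to compound 3 (0.37 log units; beyond the scatter) show. Compound 4 `CCN(CC)c1ccc2cc(C(=O)c3ccc(N4CCN(C(=O)CN5CCN(Cc6ccc(/C=C/C(=O)OC)cc6)CC5)CC4)cc3)oc2c1` differs from compound 3 in 4-(2-(methoxycarbonyl)ethenyl)phenyl in place of ethynyl on a saturated chain carbon bound to an amine nitrogen in a ring. Both measured steps that touch this position show that the small propargyl group gives a weaker compound than a sulfonyl group carrying an aromatic ring. Returning an aromatic ring at the same place, now on a saturated chain carbon, is therefore expected to lower the number, though no measured step covers this exact change. Compound 4 is expected to give 15000 nM, between 5000 nM and 60000 nM. The expected step is an at least 2.6-fold lower number from compound 3 to compound 4 (0.42 log units; beyond the scatter).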

Compound 4, half-maximal inhibitory concentration: 3040 nM
The estimate for compound 4 lay 4.9-fold (0.69 log units) above the measured number, and the stated range ends above it.
By their numbers in this assay, from the lowest: compound 4; then compounds 1 and 2 (each within the scatter of the next). At a limit, above all of these: compound 3.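

The step of an at least 13-fold lower number from compound 3 to compound 4 (1.11 log units; beyond the scatter) shows that this ring amine can carry an aromatic ring on a saturated chain carbon, with no sulfonyl group, and still give a number well clear of the limit. Compound 3 gives only a limit of the assay, so the size of this step is a floor: the limit of > 40000 nM in this assay, at which 1 of the 4 values shown sits. The change brings in the phenyl ring and its 2-(methoxycarbonyl)ethenyl part together, and the compounds shown cannot separate their shares. Going by these compounds, a plain benzyl group, or a carboxylic acid in place of the methyl ester, remains open.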